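The source may hold more compounds than are shown below. What is called first, only, known or untested is meant among the compounds shown, and "the series" means these compounds.

Three compounds built on one shared core have been examined in an ADME assay on Vero cells (Chlorocebus sabaeus) for cytotoxicity, read by neutral red uptake, tested at 3150 ug/mL; on this read-out lower numbers stand for a stronger effect and higher numbers for a weaker effect at the one concentration tested. Compound 1, `COc1ccc(C2SCC(=O)N2CCN2CCCCC2)cc1`, gives 11% in this assay. Compound 2, `O=C1CSC(c2cccc(Cl)c2)N1CCN1CCCCC1`, gives 15% in this assay, and compound 3, `COc1ccccc1C1SCC(=O)N1CCN1CCCCC1`, gives 5% in this assay. Compound 1 stands between the other two on these numbers: its closest neighbour is compound 2, whose number is higher by an amount that lies within the usual scatter of such measurements, and its furthest neighbour is compound 3, whose number is lower by an amount that also lies within that scatter. On these three numbers alone, none of the compounds can be set apart from the others.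

Compound 4, `Cc1ccc(C2SCC(=O)N2CCN2CCCCC2)cc1`, has not yet been measured in this assay. It differs from compound 1 in a single place: methyl in place of methoxy on an aromatic carbon. For the measured compounds named here, no measured pair shows what such a change does on this core, so nothing known here points to a shift in either direction. The step from compound 1 to compound 4 is therefore expected to be small, no change at the digits printed from compound 1 to compound 4 (within the scatter), and not to reach beyond the scatter. Compound 4 is estimated to give 11% in this assay, within a range from 3% to 22%.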

Compound 4, a percentage reported as activity, at one concentration (the size of the read-out at that concentration, not a potency): 12%
Compound 4: the middle estimate sits 1 percentage points below what was measured, and the stated range covers the measured number.
By their numbers in this assay, from the lowest: compounds 3, 1, 4 and 2 (each within the scatter of the next).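

In this assay, methyl in place of methoxy on an aromatic carbon, para to a large group, gives a number 1 percentage points higher from compound 1 to compound 4 (within the scatter), so this first pair on the shared core shows that the read-out does not separate these two groups at this position. The second pair, with 4-methylphenyl in place of 3-chlorophenyl on a saturated ring carbon, gives a number 3 percentage points lower from compound 2 to compound 4 (within the scatter), so exchanging the whole aromatic substituent also produces no difference that can be told from the scatter. Nothing at hand bears on why these two steps came out as they did.

Still open, on these data alone, is whether any group at this para position can move the read-out beyond the scatter, for instance an amine, a hydroxyl, a carboxylic acid or a longer chain in place of the methyl of compound 4. Also open, as far as these compounds go, is whether a methyl placed elsewhere on the aromatic ring would read the same as it does in compound 4.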